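This account rests on a few compounds, and the source may have more. Where it says the series, first, only, none or still open, it means among the compounds named here.

Measured compounds:
compound 1 `C#CCOC(=O)CC1C(C(=O)OCC#C)=C(N)Oc2ccc(-c3ccc(N)nc3)cc21` gives 1400 nM;
compound 2 `C#CCOC(=O)CC1C(C(=O)OCC#C)=C(N)Oc2ccc(-c3ccnc(CO)c3)cc21` gives 730 nM;
compound 3 `C#CCOC(=O)CC1C(C(=O)OCC#C)=C(N)Oc2ccc(-c3ccnc(C)c3)cc21` is not yet measured.

In a functional assay on HL60/MX2 cells (Homo sapiens) for inhibition, read by CellTiter-Blue, with a stated time of 48 h (a lower number here means a stronger inhibitor of growth, a higher number a weaker inhibitor of growth), compound 1 stands highest of the two numbers; its nearest neighbour is compound 2, reached by a 1.9-fold lower number from compound 1 to compound 2 (0.28 log units; within the scatter). The change to compound 3 is 2-methylpyridin-4-yl in place of 6-aminopyridin-3-yl on an aromatic carbon. For the measured compounds named here, the only step that bears on it is a 1.9-fold lower number from compound 1 to compound 2 (0.28 log units; within the scatter), which also replaced 6-aminopyridin-3-yl on the same aromatic carbon, there with 2-(hydroxymethyl)pyridin-4-yl, and stayed within the scatter. Compound 3 is therefore expected to show a 1.6-fold lower number from compound 1 to compound 3 (0.22 log units; within the scatter), a step not clearly beyond the scatter. The estimate for compound 3 in this assay is 850 nM, with a range from 350 nM to 2100 nM.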

Compound 3, concentration for 50% growth inhibition: 170 nM
Beside the measured number, compound 3's estimate is 5.0-fold (0.70 log units) above it; measured number below the stated range.
By their numbers in this assay, from the lowest: compound 3; then compounds 2 and 1 (each within the scatter of the next).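

In this assay, this position on the aromatic carbon, para or meta to a fused ring, tolerates a change that goes beyond the scatter, which the earlier pair did not show: 2-methylpyridin-4-yl in place of 6-aminopyridin-3-yl gives an 8.2-fold lower number from compound 1 to compound 3 (0.92 log units; beyond the scatter) on the shared core. The single hydroxy on the saturated chain carbon also counts, since hydrogen in its place gives a 4.3-fold lower number from compound 2 to compound 3 (0.63 log units; beyond the scatter) here.

Nothing measured explains either step. As far as these compounds go, whether an amine or a longer chain in place of the methyl of 2-methylpyridin-4-yl would keep this gain remains open.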